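Swapping the nitrogen substituent of a weak quinoline-type thiosemicarbazone

This account rests on a few compounds, and the source may have more. Where it says the series, first, only, none or still open, it means among the compounds named here.

Of the compounds shown here, three have been tested in a functional assay on HeLa cells (Homo sapiens) for antiproliferative activity, read by sulforhodamine B assay, with a stated time of 72 h; on this read-out lower numbers stand for stronger inhibition and higher numbers for weaker inhibition. Compound 1 `COc1cccc(NC(=S)N/N=C/c2ccc3ccccc3n2)c1` gives 74500 nM, the highest number of the three and therefore the weakest inhibitor here, since its gaps to both other compounds lie beyond the scatter. Compound 2 `CN(C)C(=S)N/N=C/c1ccc2cccnc2n1` gives 970 nM, and compound 3 `CN(C)C(=S)N/N=C/c1ccc2ccccc2n1` gives 90 nM. Compound 4 `S=C(NCc1ccccc1)N/N=C/c1ccc2ccccc2n1` has not been measured. It differs from compound 1 in one place: benzyl in place of 3-methoxyphenyl on an amide-type nitrogen. Among the measured compounds shown here, no measured pair shows exactly this exchange, so the direction can only be inferred from the spread above. Compound 4 is expected to give a far lower number than compound 1, a step of a 50-fold lower number from compound 1 to compound 4 (1.70 log units; beyond the scatter) in this assay. The estimated value of compound 4 is 1500 nM, within a range from 200 nM to 12000 nM.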

Compound 4, half-maximal inhibitory concentration: 62800 nM
Beside the measured number, compound 4's estimate is 42-fold (1.62 log units) below it, outside the stated range (above it).
By their numbers in this assay, from the lowest: compound 3; then compound 2; then compounds 4 and 1 (each within the scatter of the next).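

In this assay, benzyl in place of 3-methoxyphenyl on this amide-type nitrogen gives a 1.2-fold lower number from compound 1 to compound 4 (0.07 log units; within the scatter), so these two groups cannot be told apart here. Each carries one six-membered aromatic ring of carbon only, and this exchange alone does not move the number beyond the usual scatter. No measured evidence here explains this result. Still open, going by these compounds, is how a group without such a ring, such as a short chain ending in an amine or a carboxylic acid, would behave on this nitrogen.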